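This account rests on a few compounds, and the source may have more. Where it says the series, first, only, none or still open, it means among the compounds named here.

Compound 1 `CCOC(=O)c1c(CSc2nncn2C)nc2cc(OC)c(OC)cc2c1-c1ccc(OC)c(OC)c1` in a functional assay on the whole organism for inhibition, with Rattus norvegicus as the target, at a dose of 50 mg/kg by the oral route (a higher number here means more inhibition at the dose given (going by the name of the read-out), a lower number less inhibition), gives 66%. Among the two numbers reported in this assay it is the lower one; compound 2 `COC(=O)c1c(CSc2nccn2C)nc2cc(OC)c(OC)cc2c1-c1ccc(OC)c(OC)c1` gives 67% in this assay, one point higher and within the usual scatter, so no order between compound 1 and compound 2 can be read from these two values. Compound 3 `COc1ccc(-c2nc(CSc3nccn3C)nc3cc(OC)c(OC)cc23)cc1OC` is reported in this assay only as a limit, < 50%, not as a number. That limit is the limit of < 50% in this assay, at which 1 of the 3 values shown sits.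

Compound 4 `CCOC(=O)c1c(CS(=O)(=O)c2nccn2C)nc2cc(OC)c(OC)cc2c1-c1ccc(OC)c(OC)c1` has not yet been measured. It differs from compound 1 in one place: (1-methyl-1H-imidazol-2-yl)sulfonyl in place of (4-methyl-4H-1,2,4-triazol-3-yl)sulfanyl on a saturated chain carbon bound to an aromatic carbon. Among the compounds with values here, no measured pair in the set carries this change, so the size of its effect cannot be read from a measured step. Compounds 1 and 2 both carry a sulfanyl link and differ in the ester as well as in the azole, and their values lie within the scatter of each other, which gives no foothold for the sulfonyl. An estimated change of a number 11 percentage points lower from compound 1 to compound 4 (beyond the scatter) is expected, small against the scatter and not clearly in either direction. Compound 4 is therefore estimated to give 55% in this assay, expected to fall between 35% and 75%, with a fair chance that only a limit is reported.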

Compound 4, a percentage reported as inhibition, in the whole organism at one dose (the size of the read-out at that dose, not a potency): 56%
For compound 4 the middle estimate is 1 percentage points below the measured one, and the stated range covers the measured number.
By their numbers in this assay, from the lowest: compounds 4, 1 and 2 (each within the scatter of the next, the first and the last beyond it). At a limit, below all of these: compound 3.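

In this assay, within the data shown here, the exchange of (4-methyl-4H-1,2,4-triazol-3-yl)sulfanyl for (1-methyl-1H-imidazol-2-yl)sulfonyl on a saturated chain carbon bound to an aromatic carbon gives the first step that can be read at this position: a number 10 percentage points lower from compound 1 to compound 4 (within the scatter). The position therefore takes a sulfonyl link and an imidazole ring together without a change beyond the scatter, and compound 4 is still reported as a number. Compound 3 remains the only compound reported as a limit: the limit of < 50% in this assay, at which 1 of the 4 values shown sits.

The step changes the ring and the oxidation state of the sulfur link at once, so the compounds shown cannot separate the share of the sulfonyl from that of the imidazole, and they give no cause for either. Also open, from the compounds shown here alone, are the (1-methyl-1H-imidazol-2-yl)sulfinyl group, the sulfonyl paired with the 4-methyl-4H-1,2,4-triazol-3-yl ring, and an amine such as morpholine or a longer chain at this same place on the core of compound 1.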